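The source may hold more compounds than are shown below. What is called first, only, known or untested is meant among the compounds shown, and "the series" means these compounds.

Compound 2 `FC(F)Oc1ccccc1C1Cc2nccn2C1` shares its core with compound 1 `Fc1ccccc1C1Cc2nccn2C1`, which in a functional assay on CHO cells for agonist activity at Alpha-1B adrenergic receptor (Homo sapiens), read by FLIPR and calcium flux (a higher number here means that more compound is needed for the effect, a lower number that less compound is needed), gives 1770 nM. For compound 2 itself the entry in this assay reads "not determined" (no result reported), so it stands without a number of its own. Compound 3 `N#Cc1ccccc1C1Cc2nccn2C1` differs from compound 2 by cyano in place of difluoromethoxy on an aromatic carbon. Within the data shown here, no measured step covers this change, and compound 1 is the only anchor, so only a rough expectation is possible. Compound 3 is expected to fall near compound 1, with an estimated value in this assay of 1500 nM, between 400 nM and 6000 nM.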

Compound 3, half-maximal effective concentration: > 10000 nM
Compound 3 gave a limit, no number (the forecaster's own chance of this, stated with the estimate: 15%); at least 6.6-fold (0.82 log units) between middle value and limit.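

Among these compounds, with only one number among the earlier compounds, nothing could be said about how this aromatic carbon responds to a change of group, but cyano in place of fluoro now gives an at least 5.6-fold higher number from compound 1 to compound 3 (0.75 log units; beyond the scatter). The position is therefore not indifferent to what it carries. For compound 3, > 10000 nM is a limit of the assay and not a number, so the step rests on a limit: the limit of > 10000 nM in this assay, at which 1 of the 3 values shown sits.

The step involving compound 2 cannot be read, as compound 2 has no number. On these data alone, whether methyl, chloro, an amine or a carboxylic acid on this carbon would give a lower or higher number than compound 1 stays open.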